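Oxygen for sulfur on a benzimidazolyl linker

The source may report more compounds than this note shows. Statements on the series, on what has been measured and on what is new or still open speak of the compounds shown alone.

Compound 1 `CC(C)[C@H](NC(=O)COc1cccc2ccccc12)C(=O)N[C@@H](CC(=O)O)C(=O)CSc1nnc(-c2ccccc2)o1` gives 150000 nM in a functional assay on Jurkat cells (Homo sapiens) for inhibition; on this read-out higher numbers stand for weaker inhibition and lower numbers for stronger inhibition.
Compound 2 `CC(C)[C@H](NC(=O)COc1cccc2ccccc12)C(=O)N[C@@H](CC(=O)O)C(=O)CSc1nncn1C` reaches only the limit > 200000 nM in this assay, not a number.
Compound 3 `CC(C)[C@H](NC(=O)COc1cccc2ccccc12)C(=O)N[C@@H](CC(=O)O)C(=O)CSc1nc2ccccc2[nH]1` likewise reaches only the limit > 200000 nM in this assay.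

Compound 3 therefore stands at the upper edge of what this assay reports; the limit of > 200000 nM in this assay, at which 2 of the 3 values shown sit, marks where it and one further value sit. Compound 4 `CC(C)[C@H](NC(=O)COc1cccc2ccccc12)C(=O)N[C@@H](CC(=O)O)C(=O)COc1nc2ccccc2[nH]1` differs from compound 3 by (1H-benzimidazol-2-yl)oxy in place of (1H-benzimidazol-2-yl)sulfanyl on a saturated chain carbon bound to a carbonyl carbon. Going by the values given here, no measured step touches the linker atom itself. The two readable steps, an at least 1.3-fold higher number from compound 1 to compound 3 (0.12 log units; that floor lies within the scatter) and an at least 1.3-fold higher number from compound 1 to compound 2 (0.12 log units; that floor lies within the scatter), exchange the heteroaryl group on the sulfur and both end at the limit, and a step that the two limits leave unreadable from compound 2 to compound 3 cannot be sized between two limits. With nothing measured on the sulfur-to-oxygen exchange, the step expected from compound 3 is a step that the limit leaves unreadable from compound 3 to compound 4, that is, no movement beyond the scatter. Compound 4 is expected at 250000 nM, with a range from 100000 nM to 600000 nM, and most probably reported once more as a limit rather than a number.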

Compound 4, half-maximal inhibitory concentration: > 200000 nM
Compound 4 gave a limit, no number (the forecaster's own chance of this, stated with the estimate: 75%); the middle value lies beyond the limit too.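

Replacing sulfur with oxygen on the benzimidazolyl linker gives compound 4, and in this assay compound 4 gives > 200000 nM, a limit and not a number. Going by these compounds alone, the steps to compound 4 from compound 3 and from compound 2 join two limits and cannot be read, so the only readable step is an at least 1.3-fold higher number from compound 1 to compound 4 (0.12 log units; that floor lies within the scatter). The exchange of the linker atom thus has no measurable size here, and the benzimidazolyl group stays at the limit with either sulfur or oxygen: the limit of > 200000 nM in this assay, at which 3 of the 4 values shown sit.

Within the data shown here, it remains open whether oxygen would alter the result with 5-phenyl-1,3,4-oxadiazol-2-yl, the one group here that gives a number, 150000 nM for compound 1. Also open, going by these compounds, is whether an amine nitrogen or a methylene group as the linker atom, or a longer chain, would bring a value inside the limit.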